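Series notes: urea tert-butyl trimmed to isopropyl

The compounds below may be only part of what the source reports. "The series", "measured", "known", "first", "only" and "open" are said of these compounds alone.

The series shares one core, seen in compound 1 `O=C(NS(=O)(=O)c1ccc(F)cc1)c1ccc(Nc2nc(NC3(c4ccc(Cl)cc4)CC3)nc(OCC(F)(F)F)n2)cc1`, and varies the group on the sulfonyl sulfur of the acyl sulfonamide. In an ADME assay on microsomes from liver (Rattus norvegicus) for metabolic stability, with a stated time of 10 min (a lower number here means that less of the compound is left, a higher number that more of the compound is left), compound 1 gives 99%. Compound 2 `CC(C)(C)NC(=O)NCCS(=O)(=O)NC(=O)c1ccc(Nc2nc(NC3(c4ccc(Cl)cc4)CC3)nc(OCC(F)(F)F)n2)cc1` carries a urea-capped chain in place of the aryl group and gives 93% in this assay; compound 3 `CC(C)(C)CNCCS(=O)(=O)NC(=O)c1ccc(Nc2nc(NC3(c4ccc(Cl)cc4)CC3)nc(OCC(F)(F)F)n2)cc1`, with an amine-bearing chain, gives 90%. Compound 2 stands second highest of the three, with compound 3 nearest and compound 1 furthest. None of the steps separates: a number 6 percentage points lower from compound 1 to compound 2 (within the scatter), a number 9 percentage points lower from compound 1 to compound 3 (within the scatter), and a number 3 percentage points lower from compound 2 to compound 3 (within the scatter).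

Compound 4 `CC(C)NC(=O)NCCS(=O)(=O)NC(=O)c1ccc(Nc2nc(NC3(c4ccc(Cl)cc4)CC3)nc(OCC(F)(F)F)n2)cc1` is not yet measured. Against compound 2 the change is small: hydrogen in place of methyl on a saturated chain carbon bound to an amide-type nitrogen and two saturated chain carbons. The most relevant comparisons are the steps from compound 1 to compound 2 and from compound 2 to compound 3, where far larger swaps on the same side of the molecule left the read-out inside the scatter. A single methyl lost from the urea substituent is therefore expected to give no step beyond the scatter, in either direction.

For compound 4 the expected value in this assay is 91%, with a range of 80% to 99%. The step implied by this estimate is expected to be a number 2 percentage points lower from compound 2 to compound 4 (within the scatter).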

Compound 4, percent of the compound remaining: 97%
Beside the measured number, compound 4's estimate is 6 percentage points below it; the range from low to high includes it.
By their numbers in this assay, from the lowest: compounds 3, 2, 4 and 1 (each within the scatter of the next).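

In this assay, tert-butyl to isopropyl on the urea gives a number 4 percentage points higher from compound 2 to compound 4 (within the scatter), so the first direct test at this saturated chain carbon bound to an amide-type nitrogen and two saturated chain carbons shows that removing one methyl produces no step beyond the scatter. The isopropylcarbamoyl group on the amine nitrogen also stays inside the scatter against neopentyl, with a number 7 percentage points higher from compound 3 to compound 4 (within the scatter), and the whole 2-((isopropylcarbamoyl)amino)ethyl group does the same against 4-fluorophenyl on the sulfonyl sulfur, with a number 2 percentage points lower from compound 1 to compound 4 (within the scatter), so the read-out separates none of these three changes. No measurement shown here bears on the origin of these small steps, and the four compounds supply only their numbers.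

Still open, going by these compounds, is whether trimming the urea substituent further, to an ethyl or a methyl, or placing a hydroxyl on the isopropyl group, would give a step beyond the scatter. Also open is how a carboxylic acid or a longer chain on the sulfonyl sulfur would read in this assay, since the groups shown cover only aryl, urea-capped and amine-bearing chains.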